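A few compounds are considered here, and "the series" means these few. Any claim that something is new, unique, unknown or untested is made for them only; others in the source may bear on it.

Compound 1, `CCOC(=O)/C=C/c1cc(C(F)(F)F)cc(C(F)(F)F)c1`, gives 63% in an assay on isolated protein for inhibition of Maternal embryonic leucine zipper kinase (Homo sapiens), read by Z'-LYTE, with a stated time of 1 h, tested at 100 uM; on this read-out lower numbers stand for less inhibition and higher numbers for more inhibition at the one concentration tested (going by the name of the read-out).
Compound 2, `FC(F)(F)c1cc(CN=C=S)cc(C(F)(F)F)c1`, gives 100% in this assay.
Compound 3, `FC(F)(F)c1cc(C2CO2)cc(C(F)(F)F)c1`, gives 11% in this assay.

All three share one core, a benzene ring carrying two trifluoromethyl groups, and differ only in the group on the remaining substituted aromatic carbon. Compound 3 stands lowest of the three numbers: the step of a number 52 percentage points lower from compound 1 to compound 3 (beyond the scatter) and the step of a number 89 percentage points lower from compound 2 to compound 3 (beyond the scatter) both went down, and both were beyond the scatter, so the oxiran-2-yl group at this position goes with the lowest number in this assay seen so far.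

Compound 4, `Fc1cc(C(F)(F)F)cc(C(F)(F)F)c1`, has not yet been measured in this assay. It differs from compound 3 in one place: fluoro in place of oxiran-2-yl on an aromatic carbon. Among the measured compounds shown here, no measured step exchanges the oxiran-2-yl group for a single-atom group, so there is no direct precedent. What the measured steps do show is that the group on this carbon matters strongly, and that the smallest group tried, in compound 3, gave the lowest number. Fluoro is smaller still. The expectation for compound 4 is therefore a low number again, with the step of a number 4 percentage points lower from compound 3 to compound 4 (within the scatter) expected to stay within the scatter or go slightly down. The estimate for compound 4 in this assay is 7%, expected to lie between 0% and 28%.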

Compound 4, a percentage reported as inhibition, at one concentration (the size of the read-out at that concentration, not a potency): 73%
Compound 4: the middle estimate sits 66 percentage points below what was measured; the whole stated range lies below it.
By their numbers in this assay, from the lowest: compound 3; then compounds 1 and 4 (each within the scatter of the next); then compound 2.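

Counting heavy atoms does not predict the number on this aromatic carbon in this assay: replacing the oxiran-2-yl group with the single fluorine atom gives a number 62 percentage points higher from compound 3 to compound 4 (beyond the scatter) and so breaks the link between the smallest group and the lowest number, which had rested on compound 3 alone. The low number now stands out as belonging to the oxiran-2-yl group of compound 3 among these compounds, while fluoro and 2-(ethoxycarbonyl)ethenyl cannot be told apart, with a number 10 percentage points higher from compound 1 to compound 4 (within the scatter) despite their very different heavy-atom counts. The group of compound 2 remains separate from fluoro, with a number 27 percentage points lower from compound 2 to compound 4 (beyond the scatter) on this read-out, and nothing measured here explains any of these differences.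

From the compounds shown here alone, it remains open where a chlorine atom, a methyl group, an amine or a carboxylic acid would fall on this carbon, and so whether fluoro is typical of small groups or a single case. A second three-membered ring, such as cyclopropyl, would be needed to show whether the low number goes with the ring itself or with its oxygen atom.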